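From Phenyl to Methyl on Compound 1

The source may hold more compounds than are shown below. What is called first, only, known or untested is meant among the compounds shown, and "the series" means these compounds.

In a functional assay on HUVEC cells (Homo sapiens) for inhibition, read by ELISA (a lower number here means a stronger inhibitor, a higher number a weaker inhibitor), compound 1 (`COc1c(C)cnc(C[S+]([O-])c2nnc(-c3ccccc3)o2)c1C`) gives 7000 nM and stands level with compound 2 (`[O-][S+](Cc1ccccc1)c1nnc(-c2cccs2)o1`) at 7000 nM so the two cannot be told apart on these numbers. These two measurements are all there is to go on so far, and the two structures differ in more than one place. No single structural change has therefore been tested in isolation.

Compound 3 (`COc1c(C)cnc(C[S+]([O-])c2nnc(C)o2)c1C`) is still to be measured. It keeps the rest of compound 1 but carries methyl in place of phenyl on an aromatic carbon so a whole ring gives way to a single carbon.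

With no direct comparison available, the expectation is cautious: a modest step toward a weaker inhibitor, not far beyond the usual scatter of repeat measurements. An estimated 1.7-fold higher number from compound 1 to compound 3 (0.23 log units; within the scatter) is what this comes to. For compound 3 the estimate is 12000 nM with 4000 nM to 40000 nM as the expected range.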

Compound 3, half-maximal inhibitory concentration: 10000 nM
Compound 3: the middle estimate sits 1.2-fold (0.08 log units) above what was measured; measured number inside the range.
By their numbers in this assay, from the lowest: compounds 1, 2 and 3 (each within the scatter of the next).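

Going by these compounds alone, replacing phenyl with methyl on the aromatic carbon of the five-membered ring, in this assay, gives a 1.4-fold higher number from compound 1 to compound 3 (0.15 log units; within the scatter), which is the first change tested on its own. A group of 6 heavy atoms, including one six-membered aromatic ring of carbon only, gives way to a group of 1 heavy atom, yet the two compounds cannot be told apart, so on the core of compound 1 the phenyl ring is not needed to keep this level of inhibition, modest as that level is. Nothing at hand explains why so large a change in the group leaves the number within the scatter.

This single pair cannot show whether the position tolerates other groups, such as an ethyl group, a longer chain, an amine or a carboxylic acid, or whether any of these would move the number clearly beyond the scatter in either direction. It also leaves open whether the same swap would behave alike on a different core, such as that of compound 2, which differs from compound 1 in more than one place.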